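Adding a Trifluoromethyl Group to the Benzyl Side Chain

This account rests on a few compounds, and the source may have more. Where it says the series, first, only, none or still open, it means among the compounds named here.

Measured compounds:
compound 1, `O=C1C=CC2(C=C1)OCCC(=O)N2c1ccccc1`: 1300 nM
compound 2, `O=C1C=CC2(C=C1)OCC(Cc1ccccc1)C(=O)N2c1ccccc1`: 570 nM

Of the compounds shown here, two have been tested in a functional assay on BV-2 cells (Mus musculus), read by Griess assay, with a stated time of 24 h; on this read-out lower numbers stand for stronger inhibition and higher numbers for weaker inhibition. Compound 1 gives 1300 nM, and compound 2 gives 570 nM. Going by the values given here, the only measured step is a 2.3-fold lower number from compound 1 to compound 2 (0.36 log units; beyond the scatter), so compound 2 stands at the lowest number of the two, with compound 1 as its only neighbour.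

Compound 3, `O=C1C=CC2(C=C1)OCC(Cc1ccc(C(F)(F)F)cc1)C(=O)N2c1ccccc1`, has not yet been measured. It differs from compound 2 by trifluoromethyl in place of hydrogen on an aromatic carbon. Viewed one bond further out, the phenyl becomes a 4-(trifluoromethyl)phenyl.

Among the compounds with values here, no measured step speaks to this change: the one step in hand concerns benzyl in place of hydrogen on a saturated ring carbon, not a substituent on the aromatic ring of that benzyl group. With nothing to lean on, no step beyond the scatter is expected, so the estimated step is a 1.1-fold lower number from compound 2 to compound 3 (0.06 log units; within the scatter). Compound 3 is therefore expected to give 500 nM in this assay, with a range from 200 nM to 1500 nM.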

Compound 3, half-maximal inhibitory concentration: 1650 nM
Estimate against measurement, compound 3: 3.3-fold (0.52 log units) below, outside the stated range (above it).
By their numbers in this assay, from the lowest: compound 2; then compounds 1 and 3 (each within the scatter of the next).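

In this assay, placing trifluoromethyl on the aromatic ring of the benzyl side chain, para to a large group, gives a 2.9-fold higher number from compound 2 to compound 3 (0.46 log units; beyond the scatter) and marks this ring as a place where a single added group can change the read-out beyond the scatter. The earlier step, a 2.3-fold lower number from compound 1 to compound 2 (0.36 log units; beyond the scatter) when benzyl took the place of hydrogen on a saturated ring carbon, showed only that adding the side chain itself went with a lower number; the new step shows that what the side chain carries also matters, and that the number can move in the opposite direction. No measured property of these compounds bears on this result, and the reason for the change remains unknown.

The compounds shown leave open whether a single fluorine, a methyl or a methoxy at the same ring carbon would move the number as trifluoromethyl does, or whether trifluoromethyl on another carbon of that ring would have the same effect. They also leave open how a longer chain, such as phenylethyl in place of benzyl, would behave.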